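The source may report more compounds than this note shows. Statements on the series, on what has been measured and on what is new or still open speak of the compounds shown alone.

Three compounds share one core and differ only in the group on the pendant phenyl ring. In an assay on cells for inhibition of matrix metalloproteinase-9 (Homo sapiens), read by fluorescence, with stated times of 15 min and 4 h (on this read-out higher numbers stand for weaker inhibition and lower numbers for stronger inhibition), compound 1 `O=C(O)c1ccc(-c2nc3ccc(Br)cc3[nH]2)cc1` gives 27000 nM, compound 2 `Nc1ccc(-c2nc3ccc(Br)cc3[nH]2)cc1` gives 21700 nM, and compound 3 `O=[N+]([O-])c1ccc(-c2nc3ccc(Br)cc3[nH]2)cc1` gives 10000 nM. Compound 3 stands lowest of the three and is the strongest inhibitor here, both steps toward it lying beyond the scatter: a 2.2-fold lower number from compound 2 to compound 3 (0.34 log units; beyond the scatter) and a 2.7-fold lower number from compound 1 to compound 3 (0.43 log units; beyond the scatter). Compound 4 `Cc1ccc2nc(-c3ccc([N+](=O)[O-])cc3)[nH]c2c1` alters a different part of the molecule: methyl in place of bromo on an aromatic carbon. Within the data shown here, none of the measured steps touches that position; all three concern the phenyl group. With nothing to guide a direction, for compound 4 the expected step is no change at the digits printed from compound 3 to compound 4 (within the scatter), nothing beyond the scatter. Compound 4 is therefore estimated at 10000 nM, with a range from 3000 nM to 30000 nM.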

Compound 4, half-maximal inhibitory concentration: 22000 nM
For compound 4 the middle estimate is 2.2-fold (0.34 log units) below the measured one; measured number inside the range.
By their numbers in this assay, from the lowest: compound 3; then compounds 2, 4 and 1 (each within the scatter of the next).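

Replacing bromo with methyl is the first change shown away from the phenyl group, and it matters: in this assay there is a 2.2-fold higher number from compound 3 to compound 4 (0.34 log units; beyond the scatter). The step is modest, but it shows that the group on this aromatic carbon can shift the read-out, with bromo giving the lower number in this pair. No measurement here explains the difference. Chloro, methoxy or an amine at this carbon could show how other groups behave here. From the compounds shown here alone, whether the step would be the same with amino or carboxy on the phenyl ring also remains open.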